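This account rests on a few compounds, and the source may have more. Where it says the series, first, only, none or still open, it means among the compounds named here.

Three close relatives of a single core have been tested, and all three sit at the edge of what a functional assay on K562 cells (Homo sapiens) (a higher number here means a weaker inhibitor, a lower number a stronger inhibitor), can read. Compound 1, `CN(C)c1nc(N)c2ncn([C@@H]3C[C@@H](O)[C@H](CO)O3)c2n1`, gives > 300 uM in this assay, a limit rather than a number. Compound 2, `CN(C)c1nc(Br)nc2c1ncn2[C@@H]1C[C@@H](O)[C@H](CO)O1`, likewise gives > 300 uM, again a limit. Compound 3, `CSc1nc(N(C)C)c2ncn([C@@H]3C[C@@H](O)[C@H](CO)O3)c2n1`, gives > 300 uM, also a limit. The one-step change from compound 2 to compound 3, methylsulfanyl in place of bromo on an aromatic carbon, therefore reads as a step that the two limits leave unreadable from compound 2 to compound 3, because of the limit of > 300 uM in this assay, at which 3 of the 3 values shown sit.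

Compound 4, `CNc1nc(Br)nc2c1ncn2[C@@H]1C[C@@H](O)[C@H](CO)O1`, differs from compound 2 by hydrogen in place of methyl on a nitrogen on an aromatic ring. Within the data shown here, no measured step bears directly on this change, and the only step among the measured compounds cannot be sized, so the size and direction of a number no higher from compound 2 to compound 4 (the limit leaves the size open) are expected to remain unreadable, with compound 4 most likely staying at the same limit. The estimate for compound 4 in this assay is 300 uM, within a range from 100 uM to 1000 uM.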

Compound 4, concentration for 50% inhibition: 110 uM
The estimate for compound 4 lay 2.7-fold (0.44 log units) above the measured number; the measured number falls inside the stated range.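

In this assay, hydrogen in place of methyl on a nitrogen on an aromatic ring gives an at least 2.7-fold lower number from compound 2 to compound 4 (0.43 log units; beyond the scatter), and compound 4 is the only compound shown that gives a number rather than a limit. Compounds 1, 2 and 3 all carry dimethylamino, so they could not show that going from dimethylamino to methylamino matters at this place, at least with bromo on the shared core. From the compounds shown here alone, the true size of the step stays open because compound 2 gives only a limit: the limit of > 300 uM in this assay, at which 3 of the 4 values shown sit.

Going by these compounds, it remains open whether a longer chain on this nitrogen, such as ethyl or propyl, would keep the gain or lose it. The compounds shown also leave open whether methylamino has the same effect with methylsulfanyl in place of bromo.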